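Cytotoxicity notes on a benzoxaborole chalcone series

The source may hold more compounds than are shown below. What is called first, only, known or untested is meant among the compounds shown, and "the series" means these compounds.

Measured so far:
compound 1 `O=C(/C=C/c1ccc2c(c1)B(O)OC2)c1ccccc1O`, > 10 ug/mL
compound 2 `OB1OCc2ccc(/C=C/C(O)c3ccccc3)cc21`, 2.88 ug/mL
compound 3 `CSc1ccc(C(=O)/C=C/c2ccc3c(c2)B(O)OC3)cc1`, > 10 ug/mL

In an ADME assay on L929 cells (Mus musculus) for cytotoxicity, read by resazurin assay, with a stated time of 72 h (on this read-out lower numbers stand for stronger inhibition and higher numbers for weaker inhibition), compound 1 gives only a limit, > 10 ug/mL. Compound 3 likewise reaches only a limit in this assay, > 10 ug/mL. Among the compounds with values here, compound 2 is the one member with a number in this assay, 2.88 ug/mL. Within the data shown here, compound 1 therefore stands at the limit of > 10 ug/mL in this assay, at which 2 of the 3 values shown sit, with no measured step to any other compound.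

The next compound is compound 4 `O=C(/C=C/c1ccc2c(c1)B(O)OC2)c1cccc(F)c1`, differing from compound 1 by 3-fluorophenyl in place of 2-hydroxyphenyl on a carbonyl carbon. Compound 3 shows that another substituted phenyl on the carbonyl also sits at the limit, so no step beyond the scatter in this assay is expected from compound 1 to compound 4; the estimated step that the limit leaves unreadable from compound 1 to compound 4 is essentially none.

For compound 4 the expected value in this assay is 15 ug/mL, estimated to lie between 5 ug/mL and 45 ug/mL, most likely reported again as a limit.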

Compound 4, half-maximal inhibitory concentration: > 10 ug/mL
Compound 4: no number, only a limit (the forecaster's own chance of this, stated with the estimate: 70%); the middle value lies beyond the limit too.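

The step between compound 1 and compound 4 cannot be read, because both stop at a limit in this assay: the limit of > 10 ug/mL in this assay, at which 3 of the 4 values shown sit. Going by these compounds, whether 3-fluorophenyl in place of 2-hydroxyphenyl changes the cytotoxicity at all stays open.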